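Swapping a pyridine for a phenyl ring in compound 1

The compounds below may be only part of what the source reports. "The series", "measured", "known", "first", "only" and "open" are said of these compounds alone.

Of the compounds shown here, three have been tested in a functional assay on HEK293 cells for agonist activity at probable G-protein coupled receptor 27 (Homo sapiens), read by a luciferase reporter and beta-arrestin recruitment, with a stated time of 10 min; on this read-out higher numbers stand for an effect only at larger amounts of compound and lower numbers for an effect already at smaller amounts. Compound 1 `O=C(Nc1ccc(S(=O)(=O)Nc2ccccc2)cc1)c1ccc(Cl)nc1F` is the only one of them with a number: in this assay compound 1 gives 2290 nM. The other two results are limits of the assay rather than numbers. For compound 2 `O=C(Nc1ccc(S(=O)(=O)Nc2ncccn2)cc1)c1ccc(Cl)cc1Cl`, this assay reports only a limit, > 100000 nM. For compound 3 `O=C(Nc1ccc(Cl)cc1Cl)c1ccc(S(=O)(=O)Nc2ccccc2)cc1`, this assay likewise reports only a limit, > 100000 nM. For the measured compounds named here, the overall picture is therefore one of the limit of > 100000 nM in this assay, at which 2 of the 3 values shown sit, with compound 1 standing alone as the single measured value.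

Compound 4 `O=C(Nc1ccc(S(=O)(=O)Nc2ccccc2)cc1)c1ccc(Cl)cc1F` has not yet been measured. It differs from compound 1 in one place: 4-chloro-2-fluorophenyl in place of 6-chloro-2-fluoropyridin-3-yl on a carbonyl carbon. Going by the values given here, compounds 2 and 3 each differ from compound 1 in more than one place, so no single step between measured compounds is available to gauge this change, and compound 1 alone anchors the expectation. Among the compounds with values here, with no such step to lean on, the expected change is a 1.1-fold higher number from compound 1 to compound 4 (0.04 log units; within the scatter), a step that may well stay within the usual scatter of repeated measurements. Compound 4 is accordingly estimated to give 2500 nM in this assay, within a range from 700 nM to 9000 nM.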

Compound 4, half-maximal effective concentration: 3980 nM
Compound 4: middle estimate off by 1.6-fold (0.20 log units), on the low side; the measured number falls inside the stated range.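

Exchanging the 6-chloro-2-fluoropyridin-3-yl group on the carbonyl carbon for 4-chloro-2-fluorophenyl gives, in this assay, a 1.7-fold higher number from compound 1 to compound 4 (0.24 log units; within the scatter) and so compound 1 and compound 4 cannot be told apart on this read-out. For the compounds shown here, this is the first step that can be read at this position, and it shows that the measurable response survives when the ring nitrogen and the hydrogen-bond acceptor counted with it are gone, so that nitrogen is not required for a response. Nothing measured here speaks to why the two rings behave alike.

Compounds 2 and 3 each differ from compound 1 in more than one place, so they cannot show how much the chlorine or the fluorine on this ring contributes to the response. As far as these compounds go, it also remains open whether this position tolerates a more different group, such as a carboxylic acid or an amine on the ring, or a methoxy group in place of the chlorine, or whether such a group would move the number beyond the usual scatter.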